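Swapping the amine ring at the chain end of compound 1

This account rests on a few compounds, and the source may have more. Where it says the series, first, only, none or still open, it means among the compounds named here.

The account concerns compound 1, `CN1CCCN(C(=O)CCCOc2cc(C(=O)N3CCCCc4sccc43)ccc2NC(=O)c2ccccc2-c2ccccc2)CC1`, the shared core of this small set. Going by the values given here, in a functional assay on the whole organism for antagonist activity, with Rattus norvegicus as the target (a higher number here means that more compound is needed for the effect, a lower number that less compound is needed), compound 1 gives 0.008 mg/kg, the lowest of the two numbers known. The other measured compound, compound 2, `CN(C)CCN1CCCN(C(=O)c2ccc(NC(=O)c3ccccc3-c3ccccc3)cc2)c2ccsc21`, differs in several places at once; in this assay compound 2 gives 0.31 mg/kg, a number well beyond the scatter above that of compound 1. Among the compounds with values here, no pair of measured compounds differs in one place, so no single step is known.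

Compound 3, `CN(C)C1CCN(C(=O)CCCOc2cc(C(=O)N3CCCCc4sccc43)ccc2NC(=O)c2ccccc2-c2ccccc2)CC1`, differs from compound 1 in one place: 4-(dimethylamino)piperidin-1-yl in place of 4-methyl-1,4-diazepan-1-yl on a carbonyl carbon. The group that leaves and the group that enters are close in count of heavy atoms and in donors and acceptors, and the position on the carbonyl carbon is unchanged. The step from compound 1 to compound 3 in this assay is therefore expected to be small, a 1.5-fold higher number from compound 1 to compound 3 (0.18 log units; within the scatter), within the scatter or only slightly upward. Compound 3 is estimated at 0.012 mg/kg, with a range from 0.004 mg/kg to 0.04 mg/kg.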

Compound 3, dose for 50% inhibition: 0.005 mg/kg
For compound 3 the middle estimate is 2.4-fold (0.38 log units) above the measured one, and the stated range covers the measured number.
By their numbers in this assay, from the lowest: compounds 3 and 1 (each within the scatter of the next); then compound 2.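

Going by these compounds alone, the step at this carbonyl carbon is the first single change known in this set: in this assay, 4-(dimethylamino)piperidin-1-yl in place of 4-methyl-1,4-diazepan-1-yl gives a 1.6-fold lower number from compound 1 to compound 3 (0.20 log units; within the scatter) and so does not separate the two groups. A seven-membered ring with 2 hetero atoms and a six-membered ring with 1 hetero atom can therefore stand at this position with no difference beyond the scatter. Nothing measured here bears on why the two groups read alike.

The compounds shown leave open whether the chain end needs a second ring nitrogen at all, which a morpholine or a carboxylic acid on the same carbonyl carbon would address. They also leave open whether a longer chain between that carbonyl and the shared core would change the number.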